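Substituent changes on the benzyl ether arm

This account rests on a few compounds, and the source may have more. Where it says the series, first, only, none or still open, it means among the compounds named here.

Measured compounds in an assay on a cell-free system (plasma) for antagonist activity at proteinase-activated receptor 4 (Homo sapiens), with a stated time of 5 min, in the presence of a further agent that is not named here; on this read-out higher numbers stand for weaker inhibition and lower numbers for stronger inhibition:
compound 1, `COc1cc(OCc2cccc(O)c2)c2cc(-c3cn4nc(OC)sc4n3)oc2c1`: 2700 nM
compound 2, `COc1cc(OCc2cccc(Sc3ccccc3)c2)c2cc(-c3cn4nc(OC)sc4n3)oc2c1`: 410 nM
compound 3, `COc1cc(OCc2cccc(C#N)c2)c2cc(-c3cn4nc(OC)sc4n3)oc2c1`: 820 nM

Compound 3 gives the second highest number of the three: compound 2 lies within the scatter of it, while compound 1 stands clearly higher. Compound 4, `COc1cc(OCc2cccc(Oc3ccccc3)c2)c2cc(-c3cn4nc(OC)sc4n3)oc2c1`, differs from compound 3 by phenoxy in place of cyano on an aromatic carbon. Within the data shown here, the steps that bear on this are a 3.3-fold lower number from compound 1 to compound 3 (0.52 log units; beyond the scatter) and a 6.6-fold lower number from compound 1 to compound 2 (0.82 log units; beyond the scatter), both from the same starting point, while a 2.0-fold higher number from compound 2 to compound 3 (0.30 log units; within the scatter) shows the phenylsulfanyl and cyano variants close together. Phenoxy shares with phenylsulfanyl a second six-membered aromatic ring of carbon only, so a number near that of compound 2 is expected. Only a small step is expected, a 1.6-fold lower number from compound 3 to compound 4 (0.21 log units; within the scatter), which need not exceed the scatter. The estimate for compound 4 in this assay is 500 nM, range 200 nM to 1300 nM.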

Compound 4, half-maximal inhibitory concentration: 390 nM
The estimate for compound 4 lay 1.3-fold (0.11 log units) above the measured number; low and high end bracket the measured number.
By their numbers in this assay, from the lowest: compounds 4, 2 and 3 (each within the scatter of the next, the first and the last beyond it); then compound 1.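

In this assay phenoxy separates from cyano, with a 2.1-fold lower number from compound 3 to compound 4 (0.32 log units; beyond the scatter) as a step beyond the scatter, whereas the phenylsulfanyl and cyano variants stayed within it. Phenoxy and phenylsulfanyl cannot be told apart, with a 1.1-fold lower number from compound 2 to compound 4 (0.02 log units; within the scatter) as their step, while placing phenyl on the oxygen of the hydroxy group gives a 6.9-fold lower number from compound 1 to compound 4 (0.84 log units; beyond the scatter) as a step beyond the scatter. No measured evidence explains these steps. Still open, going by these compounds, is how an amine or a carboxylic acid at this position would compare. Also open, on these data alone, is whether a longer chain carrying the phenyl ring would hold the numbers of compound 2 and compound 4.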